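The source may report more compounds than this note shows. Statements on the series, on what has been measured and on what is new or still open speak of the compounds shown alone.

Four compounds built on one shared core are taken up here. Compound 1 `O=C(/C=C/c1ccc(OCc2cn(Cc3ccccc3F)nn2)cc1)c1ccc(Br)cc1` is tested in a functional assay on MCF7 cells (Homo sapiens) for inhibition, read by MTT assay, with a stated time of 48 h, tested at 10 uM (a lower number here means less inhibition of growth, a higher number more inhibition of growth at the concentration tested), and gives 38%. Compound 2 `O=C(/C=C/c1ccc(OCc2cn(Cc3cccc(F)c3)nn2)cc1)c1ccc(Br)cc1` differs from compound 1 by 3-fluorophenyl in place of 2-fluorophenyl on a saturated chain carbon bound to an aromatic nitrogen; in this assay compound 2 gives 42%, so that the step from compound 1 to compound 2 reads a number 4 percentage points higher from compound 1 to compound 2 (within the scatter). Compound 3 `O=C(/C=C/c1ccc(OCc2cn(Cc3ccccc3F)nn2)cc1)c1ccc([N+](=O)[O-])cc1` keeps the same fluorobenzyl arm as compound 1 but carries a different core, and in this assay compound 3 gives 33%, a step of a number 5 percentage points lower from compound 1 to compound 3 (within the scatter). All three values lie within the usual scatter of one another, so no order among them can be read from these numbers.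

Compound 4 `O=C(/C=C/c1ccc(OCc2cn(Cc3cccc(F)c3)nn2)cc1)c1ccc([N+](=O)[O-])cc1` has not yet been measured. It differs from compound 3 by 3-fluorophenyl in place of 2-fluorophenyl on a saturated chain carbon bound to an aromatic nitrogen, the same change that separates compound 1 from compound 2, now made on the core of compound 3; the two cores differ by nitro in place of bromo on an aromatic carbon. Within the data shown here, since the change occurs at the same place in both pairs, the earlier step is the only guide to its size. Because the step from compound 1 to compound 2 in this assay was a number 4 percentage points higher from compound 1 to compound 2 (within the scatter), a step within the scatter, compound 4 is expected to sit close to compound 3, and the expected step is a number 4 percentage points higher from compound 3 to compound 4 (within the scatter). Compound 4 is therefore estimated to give 37% in this assay, with a range from 27% to 47%.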

Compound 4, percent growth inhibition at one concentration: 30%
Beside the measured number, compound 4's estimate is 7 percentage points above it, and the stated range covers the measured number.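

On the core of compound 3, replacing 2-fluorobenzyl with 3-fluorobenzyl gives a number 3 percentage points lower from compound 3 to compound 4 (within the scatter) in this assay, and this step cannot be told apart from the one seen for the same change on the core of compound 1: the same change on two cores in this assay, a number 4 percentage points higher (within the scatter) from compound 1 to compound 2 and a number 3 percentage points lower (within the scatter) from compound 3 to compound 4, 7 percentage points apart, within the scatter of two such steps

The second change, nitro in place of bromo on an aromatic carbon, gives a number 12 percentage points lower from compound 2 to compound 4 (beyond the scatter), the only step among these compounds that goes beyond the scatter, yet it too cannot be told apart from its counterpart on the 2-fluorobenzyl pair: the same change on two cores in this assay, a number 5 percentage points lower (within the scatter) from compound 1 to compound 3 and a number 12 percentage points lower (beyond the scatter) from compound 2 to compound 4, 7 percentage points apart, within the scatter of two such steps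

Among these compounds, both changes are therefore compatible with carrying from one core to the other in this small set, but this rests on only two pairs for each change, with three of the four steps within the scatter, and it neither fixes the size of either step nor shows that the fluorine position matters at all.

The compounds shown leave open whether an amine or a carboxylic acid in place of the nitro or bromo group would follow the same pattern, and whether a longer chain carrying the fluorophenyl ring would do so. They also leave open whether the small gaps seen at this single concentration would hold in a full concentration series or in other cell lines.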